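Replacing the terminal bromine of compound 1

The source may report more compounds than this note shows. Statements on the series, on what has been measured and on what is new or still open speak of the compounds shown alone.

- compound 1 `COc1ccc(-c2coc3cc(OCCCBr)ccc3c2=O)cc1`: 64900 nM
- compound 2 `COc1ccc(-c2coc3cc(OCCCCSC(=S)N4CCN(C(=O)OC(C)(C)C)CC4)ccc3c2=O)cc1`: 31300 nM

In a functional assay on MGC-803 cells (Homo sapiens) for inhibition, read by MTT assay, with a stated time of 48 h (a lower number here means a stronger inhibitor, a higher number a weaker inhibitor), compound 1 holds the higher of the two numbers, and its gap to compound 2 lies beyond the scatter. Compound 3 `COc1ccc(-c2coc3cc(OCCCSC(=S)N4CCN(C)CC4)ccc3c2=O)cc1` differs from compound 1 by a group of 10 heavy atoms (6 carbon, 2 nitrogen, 2 sulfur; one six-membered non-aromatic ring with 2 hetero atoms) in place of one bromine atom, on a saturated chain carbon, three bonds along the chain from an oxygen on an aromatic ring, on a saturated chain carbon, three bonds along the chain from an oxygen on an aromatic ring. Going by the values given here, no measured step covers this change. Among the compounds with values here, the only guide is compound 2 at 31300 nM, so a moderate step to a lower number in this assay, beyond the scatter, is expected. The expected change is a 4.6-fold lower number from compound 1 to compound 3 (0.67 log units; beyond the scatter). The estimated value for compound 3 is 14000 nM, with an expected range of 4000 nM to 45000 nM.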

Compound 3, half-maximal inhibitory concentration: 21900 nM
Estimate against measurement, compound 3: 1.6-fold (0.19 log units) below; the measured number falls inside the stated range.
By their numbers in this assay, from the lowest: compounds 3 and 2 (each within the scatter of the next); then compound 1.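

Putting the group of 10 heavy atoms in place of bromo, on a saturated chain carbon, three bonds along the chain from an oxygen on an aromatic ring, gives in this assay a 3.0-fold lower number from compound 1 to compound 3 (0.47 log units; beyond the scatter). Going by these compounds alone, this is the first single-place reading at this position, and it shows that the far larger group with its six-membered non-aromatic ring lowers the number modestly. Nothing measured here accounts for the step. From the compounds shown here alone, whether a morpholine ring or a primary amine at this chain carbon would lower the number further remains open.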